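The compounds below may be only part of what the source reports. "The series", "measured", "known", "first", "only" and "open" are said of these compounds alone.

Of the compounds shown here, three sharing one core have been measured in an assay on isolated protein (Oryctolagus cuniculus) with Thromboxane-A synthase (Homo sapiens) as the target, tested at 1 uM; a higher number here means more inhibition at the concentration tested (going by the name of the read-out), a lower number less inhibition. Compound 1 `O=c1c2ccccc2c(-c2cccnc2)nn1C1CCCC1` gives 97%, compound 2 `O=C(c1cccs1)n1nc(-c2cccnc2)c2ccccc2c1=O` gives 37%, and compound 3 `O=c1c2ccccc2c(-c2cccnc2)nn1CCSc1ncccn1` gives 86%. Compound 3 thus stands second of the three, beyond the scatter below compound 1 and well above compound 2. Compound 4 `O=c1c2ccccc2c(-c2cccnc2)nn1CCO` differs from compound 3 by hydroxy in place of (pyrimidin-2-yl)sulfanyl on a saturated chain carbon, two bonds along the chain from an aromatic nitrogen. Among the compounds with values here, the only measured step, a number 60 percentage points lower from compound 1 to compound 2 (beyond the scatter), concerns the group attached directly to the aromatic nitrogen rather than a change further along a chain, so it bears on this step only loosely. Because compound 1 gives 97% with a cyclopentyl group on that nitrogen, the expected step is a number 6 percentage points lower from compound 3 to compound 4 (within the scatter). Compound 4 is estimated at 80%, between 60% and 95%.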

Compound 4, a percentage reported as inhibition, at one concentration (the size of the read-out at that concentration, not a potency): 69%
Beside the measured number, compound 4's estimate is 11 percentage points above it, within the range that was stated.
By their numbers in this assay, from the lowest: compound 2; then compound 4; then compound 3; then compound 1.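

In this assay, a change at the far end of the chain registers: hydroxy in place of (pyrimidin-2-yl)sulfanyl gives a number 17 percentage points lower from compound 3 to compound 4 (beyond the scatter) in a step that leaves the group's first two chain carbons untouched. With 2-hydroxyethyl on the aromatic nitrogen, the replacement of cyclopentyl gives a number 28 percentage points lower from compound 1 to compound 4 (beyond the scatter) and the replacement of (thiophen-2-yl)carbonyl gives a number 32 percentage points higher from compound 2 to compound 4 (beyond the scatter) so this group falls between those two. No measurement available here accounts for these steps.

As far as these compounds go, whether an amine or a carboxylic acid in place of hydroxy would score nearer to compound 3 stays open. So does the effect of a longer chain carrying hydroxy.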